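The compounds below may be only part of what the source reports. "The series", "measured", "known", "first", "only" and "open" are said of these compounds alone.

Measured so far:
compound 1, `CC(C)(C)OC(=O)N1CCC(OC2CCCC(Oc3ccc(S(C)(=O)=O)cc3)C2)CC1`: > 100000 nM
compound 2, `C[C@H](CF)OC(=O)N1CCC(O[C@H]2CC[C@H](Oc3cnc(S(C)(=O)=O)cn3)CC2)CC1`: 36.8 nM

In a functional assay on isolated protein for agonist activity at Glucose-dependent insulinotropic receptor (Homo sapiens), read by HTRF and cAMP accumulation (on this read-out lower numbers stand for an effect already at smaller amounts and higher numbers for an effect only at larger amounts of compound), compound 1 returns only a limit, (the limit of > 100000 nM in this assay, at which 1 of the 2 values shown sits). For the measured compounds named here, compound 2 is the only member of the pair with a number in this assay, so it is the sole anchor. Compound 3, `CC(C)c1noc(CN2CCC(O[C@H]3CC[C@H](Oc4cnc(S(C)(=O)=O)cn4)CC3)CC2)n1`, is still to be measured. It differs from compound 2 as follows: a group of 9 heavy atoms (6 carbon, 2 nitrogen, 1 oxygen; one five-membered aromatic ring with 3 hetero atoms) in place of a group of 7 heavy atoms (4 carbon, 2 oxygen, 1 fluorine; no ring), on an amine nitrogen in a ring.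

Going by the values given here, no measured pair yet shows what such an exchange on the ring nitrogen does, so the expected step of a 1.6-fold higher number from compound 2 to compound 3 (0.21 log units; within the scatter) is small, within or just beyond the usual scatter, with a slight lean toward weaker potency. For compound 3 the estimate in this assay is 60 nM, with a range from 15 nM to 300 nM.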

Compound 3, half-maximal effective concentration: 14 nM
Compound 3: middle estimate off by 4.3-fold (0.63 log units), on the high side; the measured number lies below the stated range.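

In this assay, the amine nitrogen in a ring accepts (3-isopropyl-1,2,4-oxadiazol-5-yl)methyl in place of the fluorine-bearing group with no ring, with a 2.6-fold lower number from compound 2 to compound 3 (0.42 log units; beyond the scatter) as the first step readable at this position. A five-membered aromatic ring with 3 hetero atoms can therefore stand here without the carbonyl of compound 2. Nothing measured on these compounds accounts for this step.

On these data alone, whether the gain rests on the ring, the methyl link or the isopropyl group remains open. A cyclopropyl group in place of the isopropyl, or a plain benzyl group on this nitrogen, would help separate these parts.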